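What one trifluoromethyl may do to compound 3

This account rests on a few compounds, and the source may have more. Where it says the series, first, only, none or still open, it means among the compounds named here.

Measured so far in an ADME assay on MT4 cells (Homo sapiens) for cytotoxicity, read by MTT assay, with a stated time of 4 days (a higher number here means that more compound is tolerated, a lower number that less compound is tolerated), are three compounds:
- compound 1 `Nc1ccc2oc(-c3cccc(C(F)(F)F)c3)cc(=O)c2c1` gives 138000 nM
- compound 2 `COc1c(-c2cccc(C(F)(F)F)c2)oc2ccc(NC(C)=O)cc2c1=O` gives 201000 nM
- compound 3 `COc1c(-c2ccccc2)oc2ccc(N)cc2c1=O` gives 126000 nM

Compound 3 (126000 nM) lies within the usual scatter of both compound 1 and compound 2, so these numbers cannot separate the three. All of them are tolerated to a similar degree in this test.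

Compound 4 `COc1c(-c2cccc(C(F)(F)F)c2)oc2ccc(N)cc2c1=O`, not yet measured, differs from compound 3 in a single place: trifluoromethyl in place of hydrogen on an aromatic carbon. Among the measured compounds shown here, no measured pair shows this change on its own, so any expectation must be indirect. Compound 1 (138000 nM) and compound 2 (201000 nM) already carry trifluoromethyl, though each also differs from compound 4 elsewhere, and neither stands apart from compound 3 (126000 nM). For that reason, no step beyond the scatter is expected in this assay here, and no clear direction either. The estimate gives a 1.1-fold higher number from compound 3 to compound 4 (0.03 log units; within the scatter) as the expected step. For compound 4 the estimated value is 135000 nM (70000 nM to 230000 nM).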

Compound 4, half-maximal cytotoxic concentration: 73100 nM
The estimate for compound 4 lay 1.8-fold (0.27 log units) above the measured number, within the range that was stated.
By their numbers in this assay, from the lowest: compounds 4, 3, 1 and 2 (each within the scatter of the next, the first and the last beyond it).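

Among the compounds shown here, this is the first direct look at trifluoromethyl in place of hydrogen on an aromatic carbon, meta to a large group: in this assay the change gives a 1.7-fold lower number from compound 3 to compound 4 (0.24 log units; within the scatter), so this assay does not separate the two compounds at this position. For the compounds shown here, the two other single changes to compound 4 differ in what they show, since methoxy in place of hydrogen on an aromatic carbon gives a 1.9-fold lower number from compound 1 to compound 4 (0.28 log units; within the scatter), while hydrogen in place of acetyl on a nitrogen on an aromatic ring gives a 2.7-fold lower number from compound 2 to compound 4 (0.44 log units; beyond the scatter), the only one of the three steps that stands beyond the scatter, and only modestly. Nothing available here explains the size of any of these steps.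

On these data alone, these compounds cover only one substituent at this place, so it stays open whether a chlorine atom, a methyl group or a nitrile there would also leave the number within the scatter of compound 3. As far as these compounds go, it also stays open whether a longer chain than acetyl on the nitrogen would give a step of similar size.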